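Adding a cyano group to a very stable compound

The compounds below may be only part of what the source reports. "The series", "measured", "known", "first", "only" and "open" are said of these compounds alone.

Compound 1 `FC(F)(F)c1ccccc1-c1ccc2[nH]c(C3=NOC4(CCCCC4)C3)nc2c1`: 100%
Compound 2 `Fc1ccccc1-c1ccc2[nH]c(C3=NOC4(CCCCC4)C3)nc2c1`: 79%
Compound 3 `Fc1cccc(C(F)(F)F)c1-c1ccc2[nH]c(C3=NOC4(CCCCC4)C3)nc2c1`: 38%

These numbers come from an ADME assay on microsomes from liver (Homo sapiens) for metabolic stability, with a stated time of 10 min; on this read-out higher numbers stand for a more stable compound and lower numbers for a less stable compound. Compound 1 stands highest of the three at 100%, clearly apart from both of the others. The next compound, compound 4 `N#Cc1cc(-c2ccccc2C(F)(F)F)cc2nc(C3=NOC4(CCCCC4)C3)[nH]c12`, has not been measured yet. It differs from compound 1 by cyano in place of hydrogen on an aromatic carbon, which in words is cyano in place of hydrogen on an aromatic carbon.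

Going by the values given here, no measured compound carries a group on that fused ring, so the evidence is only indirect. The closest guide is what happened when hydrogen was replaced elsewhere in the series. Fluoro in place of hydrogen gave a number 62 percentage points lower from compound 1 to compound 3 (beyond the scatter), and trifluoromethyl in place of hydrogen gave a number 41 percentage points lower from compound 2 to compound 3 (beyond the scatter). Swapping one group for another gave a smaller change, a number 21 percentage points lower from compound 1 to compound 2 (beyond the scatter). Both replacements of hydrogen lowered the number, and compound 1 at 100% has little room to rise. A fall is therefore the more likely direction, though its size is uncertain because the new group sits on a different ring. The expected change is a number 30 percentage points lower from compound 1 to compound 4 (beyond the scatter). For compound 4 the estimated value is 70%, with an expected range from 40% to 100%.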

Compound 4, percent of the compound remaining: 68%
Compound 4: the middle estimate sits 2 percentage points above what was measured; the measured number falls inside the stated range.
By their numbers in this assay, from the lowest: compound 3; then compound 4; then compound 2; then compound 1.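

In this assay, cyano in place of hydrogen on an aromatic carbon of the six-membered ring within the fused system of two rings gives a number 32 percentage points lower from compound 1 to compound 4 (beyond the scatter) and so moves the number beyond the scatter. Going by these compounds alone, every earlier step lay on the other aromatic ring, the 2-(trifluoromethyl)phenyl group and its fluoro relatives, so this is the first sign that the fused part of the molecule also matters for this read-out, even when the entering group has only 2 heavy atoms and no ring. The drop also means that the top reading of compound 1 does not survive a small addition at this carbon, yet nothing available here explains why the number fell.

From the compounds shown here alone, it remains open whether this fall belongs to cyano itself or would follow almost any group placed on this carbon, which a comparison with an amine, a methoxy group or a carboxylic acid at the same place could settle. Going by these compounds, it is equally open whether cyano on a different carbon of that ring would give a step of similar size.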